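Ring-nitrogen substituent series: from isopropyl toward acetylpiperidinyl

The source may hold more compounds than are shown below. What is called first, only, known or untested is meant among the compounds shown, and "the series" means these compounds.

Of the compounds shown here, two have been measured in an assay on HEK-293T cells for antagonist activity at vitamin D3 receptor (Homo sapiens), read by a luciferase reporter, with a stated time of 24 h; on this read-out lower numbers stand for stronger inhibition and higher numbers for weaker inhibition. Compound 1 `CCC(CC)n1c(-c2ccc(OCc3c(-c4c(Cl)cccc4Cl)noc3C(C)C)cc2)nc2ccc(C(=O)O)cc21` gives 5690 nM in this assay. Compound 2 `CC(C)c1onc(-c2c(Cl)cccc2Cl)c1COc1ccc(-c2nc3ccc(C(=O)O)cc3n2C(C)C)cc1` gives 3550 nM in this assay. Going by the values given here, the only known step, a 1.6-fold lower number from compound 1 to compound 2 (0.20 log units; within the scatter), lies within the scatter, so compound 2 cannot be set apart from compound 1 on this read-out; the two numbers are, for working purposes, the same.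

Compound 3 `CC(=O)N1CCC(n2c(-c3ccc(OCc4c(-c5c(Cl)cccc5Cl)noc4C(C)C)cc3)nc3ccc(C(=O)O)cc32)CC1` is not yet measured. It differs from compound 2 by 1-acetylpiperidin-4-yl in place of isopropyl on an aromatic nitrogen. Among the compounds with values here, the one measured step bears on the same position on the aromatic nitrogen, but it exchanged two small alkyl groups and produced nothing beyond the scatter. Whether the larger acetylpiperidinyl group behaves like those alkyls is not shown by any measured pair, so the expectation rests on that single uninformative step and carries a wide range.

For compound 3 in this assay the estimate is 3500 nM, with a range of 1200 nM to 12000 nM. The step this estimate implies, a 1.0-fold lower number from compound 2 to compound 3 (0.01 log units; within the scatter), is expected to stay within the scatter.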

Compound 3, half-maximal inhibitory concentration: > 10000 nM
Compound 3 gave a limit, no number; the forecaster's own chance of this, stated with the estimate: 10%; middle value at least 2.8-fold (0.45 log units) away from the limit.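

In this assay compound 3 reads only as a limit of the assay and not as a number: the limit of > 10000 nM in this assay, at which 1 of the 3 values shown sits.

Going by these compounds alone, on the aromatic nitrogen, 1-acetylpiperidin-4-yl in place of isopropyl gives an at least 2.8-fold higher number from compound 2 to compound 3 (0.44 log units; beyond the scatter), the first step to lie beyond the scatter, so this position is not indifferent to the group it carries, which the exchange of two small alkyl groups could not show. The comparison with pentan-3-yl is less firm, at an at least 1.7-fold higher number from compound 1 to compound 3 (0.24 log units; that floor lies within the scatter), so this pair alone does not set compound 3 apart from compound 1, and the full size of neither step can be read.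

The enlarged group brings a six-membered non-aromatic ring, a ring nitrogen and an acetyl carbonyl together, and the compounds shown do not separate what each of these contributes to the higher number. From the compounds shown here alone, how a plain cyclohexyl group, a piperidin-4-yl group with a free amine, or a tetrahydropyran-4-yl group on this nitrogen would read in this assay stays open, as does whether any group here gives a number clearly lower than those of the small alkyl compounds.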